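Swapping chloro for methoxy on the benzyl ring

The source may hold more compounds than are shown below. What is called first, only, known or untested is meant among the compounds shown, and "the series" means these compounds.

Of the compounds shown here, three sharing one core have been tested in a functional assay on BE(2)-C cells (Homo sapiens) for inhibition, read by MTT assay, with a stated time of 72 h; on this read-out higher numbers stand for weaker inhibition of growth and lower numbers for stronger inhibition of growth. Compound 1 `O=S(=O)(NCCCNCc1ccc(Cl)cc1)c1cc(C(F)(F)F)cc(C(F)(F)F)c1` gives 2900 nM. Compound 2 `CC(C)(C)c1ccc(CNCCCNS(=O)(=O)c2cc(C(F)(F)F)cc(C(F)(F)F)c2)cc1` gives 2500 nM, and compound 3 `COc1ccccc1CNCCCNS(=O)(=O)c1cc(C(F)(F)F)cc(C(F)(F)F)c1` gives 3600 nM. Compound 1 sits second highest of these three numbers, but all three steps between them stay within the scatter: a 1.2-fold lower number from compound 1 to compound 2 (0.06 log units; within the scatter), a 1.2-fold higher number from compound 1 to compound 3 (0.09 log units; within the scatter) and a 1.4-fold higher number from compound 2 to compound 3 (0.16 log units; within the scatter). So far, changing the group on the benzyl ring, or moving it, has not shifted the read-out beyond what repeated measurements would show anyway.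

Compound 4 `COc1ccc(CNCCCNS(=O)(=O)c2cc(C(F)(F)F)cc(C(F)(F)F)c2)cc1` is the next step from compound 1. The change is methoxy in place of chloro on an aromatic carbon. Both the larger tert-butyl in compound 2 and the 2-methoxyphenyl in compound 3 left the number essentially where compound 1 stands, so no step beyond the scatter is expected in this assay. Compound 4 is estimated at 3200 nM, with a range from 1600 nM to 6400 nM, which means an expected step of a 1.1-fold higher number from compound 1 to compound 4 (0.04 log units; within the scatter).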

Compound 4, concentration for 50% growth inhibition: 2800 nM
The estimate for compound 4 lay 1.1-fold (0.06 log units) above the measured number, within the range that was stated.
By their numbers in this assay, from the lowest: compounds 2, 4, 1 and 3 (each within the scatter of the next).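

In this assay, methoxy in place of chloro, on an aromatic carbon para to a large group, gives a 1.0-fold lower number from compound 1 to compound 4 (0.02 log units; within the scatter), so this position accepts a group with a hydrogen-bond acceptor without the number leaving the scatter. For the compounds shown here, compound 4 also gives the first direct look at where methoxy sits on the ring: 4-methoxyphenyl in place of 2-methoxyphenyl gives a 1.3-fold lower number from compound 3 to compound 4 (0.11 log units; within the scatter), and methoxy in place of tert-butyl gives a 1.1-fold higher number from compound 2 to compound 4 (0.05 log units; within the scatter), so neither moving methoxy nor exchanging it for the bulkier tert-butyl separates these compounds. No measurement available here bears on why these groups read alike.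

Going by these compounds, whether a carboxylic acid or an amine on the benzyl ring would shift the number beyond the scatter remains open. So does whether a longer chain in the shared core would do so.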